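Hydrogen to Phenyl on the Sulfur-Bound Carbon

The source may report more compounds than this note shows. Statements on the series, on what has been measured and on what is new or still open speak of the compounds shown alone.

Compound 1 `Cc1nsc2c1ncn2[C@@H]1O[C@H](CO)[C@@H](O)[C@@H]1O` carries hydrogen on the aromatic carbon where compound 2 `CSc1nc2c(C)nsc2n1[C@@H]1O[C@H](CO)[C@@H](O)[C@@H]1O` carries methylsulfanyl. In a functional assay on L1210 cells (Mus musculus) for antiproliferative activity (on this read-out higher numbers stand for weaker inhibition and lower numbers for stronger inhibition), compound 1 gives only a limit, > 100000 nM. In this assay compound 2 likewise gives only a limit, > 100000 nM. The step that the two limits leave unreadable from compound 1 to compound 2 therefore cannot be read in size or direction, as both values sit at the limit of > 100000 nM in this assay, at which 2 of the 2 values shown sit. Compound 3 `Cc1nsc2c1nc(SCc1ccccc1)n2[C@@H]1O[C@H](CO)[C@@H](O)[C@@H]1O` differs from compound 2 by phenyl in place of hydrogen on a saturated chain carbon bound to a sulfur. Among the compounds with values here, no measured step resembles this change, and the single step that is available, from hydrogen to methylsulfanyl, is itself unreadable, so it offers no guide to direction or size. With both measured compounds resting at the same limit, the account expects compound 3 to stay at that limit as well, and the expected step of a number no higher from compound 2 to compound 3 (the limit leaves the size open) is accordingly none beyond the scatter. The estimate for compound 3 in this assay is 100000 nM, with an expected range from 30000 nM to 300000 nM. Whether the measurement yields a number or only another limit is decided by the reading that follows.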

Compound 3, half-maximal inhibitory concentration: > 100000 nM
Compound 3 was reported as a limit; the forecaster's own chance of this, stated with the estimate: 85%; the middle value lies on the limit itself.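

Compound 3 gives only a limit in this assay, so its steps from compound 1 and compound 2 cannot be read in size or direction: the limit of > 100000 nM in this assay, at which 3 of the 3 values shown sit.

The compounds shown leave open how strongly any of the three inhibits, and whether methylsulfanyl or benzylsulfanyl in place of hydrogen on the aromatic carbon changes activity at all.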